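This account rests on a few compounds, and the source may have more. Where it says the series, first, only, none or still open, it means among the compounds named here.

Among the compounds with values here, compound 1 `O=C(Nc1cccc(-n2cc(-c3ccncc3)c(-c3cc(O)cc(Cl)c3)n2)c1)Nc1ccc(Cl)c(C(F)(F)F)c1` is one of two compounds measured in a functional assay on Malme-3M cells (Homo sapiens) for inhibition, read by sulforhodamine B assay, with a stated time of 48 h, tested at 0.1 uM (on this read-out higher numbers stand for a weaker effect at the one concentration tested and lower numbers for a stronger effect), where compound 1 gives 81%. Its companion, compound 2 `O=C(Nc1cccc(-n2cc(-c3ccncc3)c(-c3cc(O)cc(Cl)c3)n2)c1)Nc1ccc(Cl)c(Cl)c1`, gives 84% in this assay . Within the data shown here, the single measured step between them, a number 3 percentage points higher from compound 1 to compound 2 (within the scatter), is a change at a different place in the molecule and has no bearing on the change considered here. Compound 1 stands lowest of the two numbers, with compound 2 the nearest and within the scatter of it.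

The unmeasured compound 3 `COc1cc(Cl)cc(-c2nn(-c3cccc(NC(=O)Nc4ccc(Cl)c(C(F)(F)F)c4)c3)cc2-c2ccncc2)c1` differs from compound 1 by methyl in place of hydrogen on an oxygen on an aromatic ring. Among the measured compounds shown here, no measured pair shows this change, so nothing in the data points to a step in either direction; on that basis the step is expected to be none beyond the scatter. Compound 3 is therefore estimated at 83%, between 66% and 97%, which would mean a step of a number 2 percentage points higher from compound 1 to compound 3 (within the scatter).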

Compound 3, a percentage reported as activity, at one concentration (the size of the read-out at that concentration, not a potency): 79%
Compound 3: the middle estimate sits 4 percentage points above what was measured, within the range that was stated.
By their numbers in this assay, from the lowest: compounds 3, 1 and 2 (each within the scatter of the next).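

The change from hydroxy to methoxy on the 3-chloro-5-hydroxyphenyl group is the first change shown at this position, and in this assay it gives a number 2 percentage points lower from compound 1 to compound 3 (within the scatter). The hydroxy hydrogen can therefore be replaced by methyl without a step beyond the scatter, at least at the one concentration tested and for this pair alone. No measurement available here accounts for this result.

As far as these compounds go, what remains open is whether a longer chain on the same oxygen, such as ethoxy or a propoxy group, would also leave the number within the scatter of compound 1. From the compounds shown here alone, it is equally open whether an amine or a carboxylic acid in place of the hydroxy would produce a step beyond the scatter in this assay.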